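Chloro for methyl on compound 3

A few compounds are considered here, and "the series" means these few. Any claim that something is new, unique, unknown or untested is made for them only; others in the source may bear on it.

Compound 3 (`Cc1ccc(-c2nnc(COc3ccc(C#N)c(F)c3)o2)cc1`) gives > 50000 nM in a functional assay on MDA-MB-453 cells (Homo sapiens) for cytotoxicity, read by MTT assay, with a stated time of 48 h (on this read-out lower numbers stand for stronger inhibition and higher numbers for weaker inhibition), and that value is a limit, not a number. Compound 4 (`N#Cc1ccc(OCc2nnc(-c3ccc(Cl)cc3)o2)cc1F`) has chloro in place of methyl on an aromatic carbon, para to a large group (chloro in place of methyl on an aromatic carbon). The same difference reads 4-methylphenyl to 4-chlorophenyl.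

Within the data shown here, one measured step bears on this only indirectly, as it brings in chloro in place of methoxy rather than methyl. Compound 1 (`COc1ccc(-c2nnc(COc3ccc(C#N)cc3OC)o2)cc1`) gives 13000 nM in this assay and compound 2 (`COc1cc(C#N)ccc1OCc1nnc(-c2ccc(Cl)cc2)o1`) gives 33900 nM in the same test. That is a 2.6-fold higher number from compound 1 to compound 2 (0.42 log units; beyond the scatter) and it offers no measure of a methyl replacement. Compound 2 at 33900 nM does show that the 4-chlorophenyl group can give a measured number.

A small move toward a lower number is expected, and it may not exceed the scatter. The expected change is an at least 1.2-fold lower number from compound 3 to compound 4 (0.09 log units; that floor lies within the scatter) and it remains tentative. For compound 4 the estimate is 40000 nM with an expected range of 18000 nM to 80000 nM in this series.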

Compound 4, half-maximal inhibitory concentration: > 50000 nM
Compound 4: a limit, no number; the forecaster's own chance of this, stated with the estimate: 45%; middle value at least 1.2-fold (0.09 log units) away from the limit.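

The values of compound 3 and compound 4 are both limits, not numbers, so no step between them can be read: the limit of > 50000 nM in this assay, at which 2 of the 4 values shown sit.

The compounds shown leave open whether chloro in place of methyl on an aromatic carbon changes the read-out at all, and by how much.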